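Extending the Side Chain of Compound 3

The source may hold more compounds than are shown below. What is called first, only, known or untested is meant among the compounds shown, and "the series" means these compounds.

In a functional assay on PC-3 cells (Homo sapiens) for antiproliferative activity, read by MTT assay, with a stated time of 72 h (on this read-out lower numbers stand for stronger inhibition and higher numbers for weaker inhibition), compound 1 (`O=C(N/N=C/c1cccc(Cl)c1Cl)Nc1ccc(Oc2ccnc3[nH]ccc23)cc1`) is recorded as "not active" (no number reported) with no number given. Compound 2 (`COc1ccc(/C=N/NC(=O)Nc2ccc(Oc3ccnc4[nH]ccc34)cc2)cc1`) is likewise recorded as "not active" (no number reported) with no number given. Compound 3 (`CN(C)CCn1cccc1/C=N/NC(=O)Nc1ccc(Oc2ccnc3[nH]ccc23)cc1`) gives 3930 nM and is the only one of the three with a number. Compound 4 (`CN1CCN(CCCn2cccc2/C=N/NC(=O)Nc2ccc(Oc3ccnc4[nH]ccc34)cc2)CC1`) keeps the shared core and differs from compound 3 in its side chain: (4-methylpiperazin-1-yl)methyl in place of dimethylamino on a saturated chain carbon, two bonds along the chain from an aromatic nitrogen. Among the measured compounds shown here, no measured pair shows the effect of this change, so compound 3 at 3930 nM is the only anchor for an expectation. In this assay the expected change is a 1.3-fold lower number from compound 3 to compound 4 (0.12 log units; within the scatter) and no larger than the usual scatter. Compound 4 is estimated at 3000 nM with an expected range from 900 nM to 10000 nM as the likely span.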

Compound 4, half-maximal inhibitory concentration: 3740 nM
The estimate for compound 4 lay 1.2-fold (0.10 log units) below the measured number; the range from low to high includes it.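

The replacement of dimethylamino by (4-methylpiperazin-1-yl)methyl on a saturated chain carbon, two bonds along the chain from an aromatic nitrogen, gives a 1.1-fold lower number from compound 3 to compound 4 (0.02 log units; within the scatter) in this assay. Among the compounds shown here, this is the first number-to-number comparison at this position, and it shows that the end of the chain can carry the six-membered non-aromatic ring with no change beyond the scatter. No available evidence bears on why the two compounds read alike. The compounds shown leave open whether a chain ending in a hydroxyl or a carboxylic acid instead of an amine would hold this number, and what a longer chain would do.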